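Replacing the sulfonyloxy group with an amino ester

A few compounds are considered here, and "the series" means these few. Any claim that something is new, unique, unknown or untested is made for them only; others in the source may bear on it.

In a functional assay on MDA-MB-435 cells (Homo sapiens) for cytotoxicity, read by MTT assay, with a stated time of 72 h (a higher number here means a weaker inhibitor, a lower number a stronger inhibitor), compound 1 `CN(C)CCCNc1c(C(=O)NCc2ccc(F)cc2)nc(Br)c2cccnc12` gives 7000 nM. Compound 2 `O=C(NCc1ccc(F)cc1)c1nc(Br)c2cccnc2c1NCc1ccccc1` gives only a limit, > 20000 nM. Compound 3 `Cc1ccc(S(=O)(=O)Oc2c(C(=O)NCc3ccc(F)cc3)nc(Br)c3cccnc23)cc1` also gives only a limit, > 20000 nM, and so stands at the limit of > 20000 nM in this assay, at which 2 of the 3 values shown sit. Compound 4 `COC(=O)CNc1c(C(=O)NCc2ccc(F)cc2)nc(Br)c2cccnc12` carries ((methoxycarbonyl)methyl)amino in place of ((4-methylphenyl)sulfonyl)oxy on an aromatic carbon. For the measured compounds named here, two measured steps bear on this change: an at least 2.8-fold higher number from compound 1 to compound 3 (0.45 log units; beyond the scatter) and an at least 2.8-fold higher number from compound 1 to compound 2 (0.45 log units; beyond the scatter). Both lie beyond the scatter, yet both end at a limit, so neither gives a full size. The expected step is an at least 1.3-fold lower number from compound 3 to compound 4 (0.12 log units; that floor lies within the scatter), a modest one towards a lower number, though another result at the limit would fit the data. For compound 4 the estimated value is 15000 nM, with an expected range of 6000 nM to 35000 nM.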

Compound 4, half-maximal inhibitory concentration: 10000 nM
The estimate for compound 4 lay 1.5-fold (0.18 log units) above the measured number; the range from low to high includes it.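

In this assay, ((methoxycarbonyl)methyl)amino gives a full number at this position, with an at least 2.0-fold lower number from compound 3 to compound 4 (0.30 log units; that floor lies within the scatter) and an at least 2.0-fold lower number from compound 2 to compound 4 (0.30 log units; that floor lies within the scatter). Set against the dimethylamino side chain, the change gives a 1.4-fold higher number from compound 1 to compound 4 (0.15 log units; within the scatter), so a readable number here does not require that dimethylamino group. Compound 2 and compound 3 remain at a limit of the assay: the limit of > 20000 nM in this assay, at which 2 of the 4 values shown sit.

The compounds shown leave open whether a carboxylic acid or a longer chain in place of the methoxycarbonyl group would shift the number. From the compounds shown here alone, whether the true gain over the two limits exceeds the scatter also stays open.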